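Changing the group on the aromatic nitrogen once more

The compounds below may be only part of what the source reports. "The series", "measured", "known", "first", "only" and "open" are said of these compounds alone.

Compound 2 `COc1ccc(Cn2ccc3cc(/C(C)=C/C(=O)Nc4ccccc4OCCCC(=O)O)ccc32)cc1` gives the higher of the two numbers measured in an assay on Prostate gland for inhibition of steroid 5-alpha-reductase (Rattus norvegicus) (a lower number here means a stronger inhibitor, a higher number a weaker inhibitor), at 480 nM. Compound 1 `C/C(=C\C(=O)Nc1ccccc1OCCCC(=O)O)c1ccc2c(ccn2C(C(C)C)C(C)C)c1` gives 14 nM in this assay, and the step of a 34-fold higher number from compound 1 to compound 2 (1.54 log units; beyond the scatter) is the only measured one that bears on the present change. Compound 3 `CCCCCC(c1ccccc1)n1ccc2cc(/C(C)=C/C(=O)Nc3ccccc3OCCCC(=O)O)ccc21` carries 1-phenylhexyl in place of 4-methoxybenzyl on an aromatic nitrogen. With just one prior step at this position, an account for compound 3 expects a return part of the way toward compound 1, a step of an 8.0-fold lower number from compound 2 to compound 3 (0.90 log units; beyond the scatter) toward a lower number. Compound 3 is therefore estimated at 60 nM, within 15 nM to 250 nM.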

Compound 3, half-maximal inhibitory concentration: 25 nM
Compound 3: the middle estimate sits 2.4-fold (0.38 log units) above what was measured, and the stated range covers the measured number.
By their numbers in this assay, from the lowest: compounds 1 and 3 (each within the scatter of the next); then compound 2.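

In this assay, the step of a 19-fold lower number from compound 2 to compound 3 (1.28 log units; beyond the scatter) shows that the number at this aromatic nitrogen does not simply follow the presence of a six-membered aromatic ring, since 4-methoxybenzyl and 1-phenylhexyl each carry one. The step of a 1.8-fold higher number from compound 1 to compound 3 (0.25 log units; within the scatter) leaves 1-phenylhexyl and the ring-free 1-isopropyl-2-methylpropyl indistinguishable here. Nothing available explains these results.

The compounds shown leave open which feature of the two ring-bearing groups goes with the large step: the methoxy or the chain. A plain benzyl or a 1-phenylethyl group on this nitrogen would help separate them.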